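The source may report more compounds than this note shows. Statements on the series, on what has been measured and on what is new or still open speak of the compounds shown alone.

In an assay on CHO cells for displacement of a labelled ligand from Alpha-1B adrenergic receptor (Homo sapiens) (a higher number here means a weaker inhibitor, a lower number a stronger inhibitor), compound 1 `COc1cccc(OC)c1OCCNCCOc1ccccc1OCc1cccc(Cl)c1` gives 0.159 nM, compound 2 `COc1cccc(OC)c1OCCNCCOc1ccccc1OCc1ccc(Cl)cc1` gives 1 nM, and compound 3 `COc1cccc(OC)c1OCCNCCOc1ccccc1OCc1ccccc1C` gives 0.794 nM. Compound 3 thus holds the second highest of the three numbers: the step of a 1.3-fold lower number from compound 2 to compound 3 (0.10 log units; within the scatter) lies within the scatter, whereas the step of a 5.0-fold higher number from compound 1 to compound 3 (0.70 log units; beyond the scatter) lies beyond it. All three share one core and differ only in the group on the saturated chain carbon bound to an oxygen on an aromatic ring.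

Compound 4 `COc1cccc(OC)c1OCCNCCOc1ccccc1OCc1cccc(C)c1` has not yet been measured. It differs from compound 3 in that (3-methylphenyl in place of 2-methylphenyl on a saturated chain carbon bound to an oxygen on an aromatic ring). Within the data shown here, two measured steps bear on this change. Exchanging 3-chlorophenyl for 4-chlorophenyl gave a 6.3-fold higher number from compound 1 to compound 2 (0.80 log units; beyond the scatter), and exchanging 3-chlorophenyl for 2-methylphenyl gave a 5.0-fold higher number from compound 1 to compound 3 (0.70 log units; beyond the scatter). The 3-chlorophenyl of compound 1 gives the lowest number of the set, and compound 4 carries 3-methylphenyl, which matches that group except for methyl in place of chlorine. A modest step toward a lower number in this assay is therefore expected, namely a 2.3-fold lower number from compound 3 to compound 4 (0.36 log units; beyond the scatter), allowing for a smaller shift than between compounds 1 and 3 since methyl and chlorine are not the same substituent. For compound 4 the estimate in this assay is 0.35 nM, with a range from 0.12 nM to 1 nM.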

Compound 4, inhibition constant: 0.251 nM
Beside the measured number, compound 4's estimate is 1.4-fold (0.14 log units) above it; low and high end bracket the measured number.
By their numbers in this assay, from the lowest: compounds 1 and 4 (each within the scatter of the next); then compounds 3 and 2 (each within the scatter of the next).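

Compound 3 and compound 4 have the same atoms, joined differently. Among these compounds, the step of a 3.2-fold lower number from compound 3 to compound 4 (0.50 log units; beyond the scatter) in this assay isolates the effect of moving the methyl group from 2-methylphenyl to 3-methylphenyl, whereas the earlier steps between compounds 1 and 3 changed both the substituent and its place on the ring. The other two steps add that, where compound 4 and compound 1 share this ring pattern, exchanging chloro for methyl makes no difference that can be told from the scatter, a 1.6-fold higher number from compound 1 to compound 4 (0.20 log units; within the scatter), while a 4.0-fold lower number from compound 2 to compound 4 (0.60 log units; beyond the scatter) is as clear as the change between the two methyl compounds, so among these four compounds the 3-substituted pair, compounds 1 and 4, stands apart from compounds 2 and 3, with none going against this. There is no evidence here to explain why the ring pattern matters more than the choice of methyl or chloro.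

The chloro and methyl comparison rests on this single matched pair. As far as these compounds go, whether a methoxy group, a nitrile or an amine in place of methyl or chloro on an aromatic carbon would keep the number as low remains open.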